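A few compounds are considered here, and "the series" means these few. Any claim that something is new, unique, unknown or untested is made for them only; others in the source may bear on it.

Compound 1 `O=C(NN=C1CC(c2ccccc2)NC(c2ccccc2)C1)c1ccc(F)cc1`: 66000 nM
Compound 2 `O=C(NN=C1CC(c2ccccc2)NC(c2ccccc2)C1)c1ccc(C(F)(F)F)cc1`: 65000 nM
Compound 3 `O=C(NN=C1CC(c2ccccc2)NC(c2ccccc2)C1)c1ccc([N+](=O)[O-])cc1`: 88100 nM

In a functional assay, read by spectrophotometry, with a stated time of 2 h (a lower number here means a stronger inhibitor, a higher number a weaker inhibitor), compound 3 stands at the highest of the three numbers, yet the steps of a 1.3-fold higher number from compound 1 to compound 3 (0.13 log units; within the scatter) and a 1.4-fold higher number from compound 2 to compound 3 (0.13 log units; within the scatter) both lie within the scatter, so no order among the three can be read. Compound 4 `O=C(NN=C1CC(c2ccccc2)NC(c2ccccc2)C1)c1ccc([N+](=O)[O-])cc1[N+](=O)[O-]` differs from compound 3 by nitro in place of hydrogen on an aromatic carbon. Among the compounds with values here, the steps that bear on this are the three substituent swaps on the same aromatic ring, a 1.0-fold lower number from compound 1 to compound 2 (0.01 log units; within the scatter) among them, and none of them moved this assay beyond the scatter. The change to compound 4 is therefore expected to leave this assay essentially where compound 3 stands, with no step beyond the scatter, a 1.0-fold higher number from compound 3 to compound 4 (0.01 log units; within the scatter). For compound 4 the estimate is 90000 nM, in a range from 40000 nM to 200000 nM.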

Compound 4, half-maximal inhibitory concentration: 20000 nM
The estimate for compound 4 lay 4.5-fold (0.65 log units) above the measured number; measured number below the stated range.
By their numbers in this assay, from the lowest: compound 4; then compounds 2, 1 and 3 (each within the scatter of the next).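

In this assay, a nitro group entering on an aromatic carbon, ortho to a large group and meta to a nitro group, gave a 4.4-fold lower number from compound 3 to compound 4 (0.64 log units; beyond the scatter) and so produced the first step beyond the scatter among these compounds. The earlier swaps among fluoro, trifluoromethyl and nitro on the ring had all stayed within the scatter, so this newly filled place responds where they did not. Nothing available explains the step.

As far as these compounds go, whether the step is specific to nitro remains open, as an amine, a methoxy group or a chlorine atom at this place could show. Also open, from the compounds shown here alone, is whether this nitro would give the same step alongside fluoro or trifluoromethyl in place of the existing nitro.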